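The compounds below may be only part of what the source reports. "The series", "measured", "known", "first", "only" and "open" are said of these compounds alone.

Of the compounds shown here, three built on one shared core have been tested in a functional assay on NCI-H322M cells (Homo sapiens) for cytotoxicity, read by sulforhodamine B assay, with a stated time of 48 h, tested at 0.01 uM; a higher number here means a weaker effect of the compound at the concentration tested, a lower number a stronger effect. Compound 1 `COc1ccc(-c2cc(/C=C/C(=O)c3ccc(N)cc3)[nH]n2)cc1` gives 95%. Compound 2 `COc1ccc(C(=O)/C=C/c2cc(-c3cc(OC)c(OC)c(OC)c3)n[nH]2)cc1` gives 92%, and compound 3 `COc1cc(-c2cc(/C=C/C(=O)c3ccc(F)c(F)c3)[nH]n2)cc(OC)c1OC` gives 94%; each of these two numbers lies within the usual scatter of the number of compound 1, so on these readings the three compounds cannot be told apart.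

For the measured compounds named here, only one pair of measured compounds differs in a single place, and that step, a number 2 percentage points higher from compound 2 to compound 3 (within the scatter), came with 3,4-difluorophenyl in place of 4-methoxyphenyl on a carbonyl carbon.

Compound 4 `COc1ccc(-c2cc(/C=C/C(=O)c3ccc(N)cc3)[nH]n2)cc1OC` has not yet been measured. It differs from compound 1 by methoxy in place of hydrogen on an aromatic carbon; the new group sits on an aromatic carbon of a six-membered aromatic ring of carbon only, ortho to a methoxy group and meta to a large group. Going by the values given here, no measured step touches this part of the core, and the one step that does exist stayed within the scatter. There is therefore no basis for expecting a step beyond the scatter in either direction.

Compound 4 is expected to give about 94% in this assay, within a range from 86% to 100%. That estimate means a step of a number 1 percentage points lower from compound 1 to compound 4 (within the scatter), which is expected to remain inside the usual scatter.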

Compound 4, a percentage reported as activity, at one concentration (the size of the read-out at that concentration, not a potency): 96%
Compound 4: the middle estimate sits 2 percentage points below what was measured; low and high end bracket the measured number.
By their numbers in this assay, from the lowest: compounds 2, 3, 1 and 4 (each within the scatter of the next).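

For the compounds shown here, the added methoxy on an aromatic carbon, ortho to a methoxy group and meta to a large group, gives the first measured step at this part of the core. In this assay, the swap of hydrogen for methoxy leaves the reading within the usual scatter (a number 1 percentage points higher from compound 1 to compound 4 (within the scatter)), so compound 4 cannot be told apart from compound 1 at this single concentration, and this position takes the extra group with no visible change in the read-out. No measured evidence on either compound bears on this result.

Going by these compounds, whether a different group at this same position, such as a hydroxyl, a fluorine, an amine or a longer chain like ethoxy, would move the reading beyond the scatter remains open. Also open, on these data alone, is whether compound 1 and compound 4 would still look alike at higher concentrations, where a read-out further from the values seen so far could separate them, as a single low concentration gives the size of an effect and not a potency.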